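Cyclopropylmethoxy in place of chloro on a nitroimidazooxazine amine

The source may report more compounds than this note shows. Statements on the series, on what has been measured and on what is new or still open speak of the compounds shown alone.

Of the compounds shown here, three sharing one core have been measured in an in vitro ADME assay on the whole organism (microsomes, liver, Mus musculus) for metabolic stability, read by LC-MS, with a stated time of 24 h, at a dose of 5 mg/kg by the intravenous route; a lower number here means that the compound disappears faster, a higher number that the compound lasts longer. Compound 1, `O=[N+]([O-])c1cn2c(n1)OC[C@@H](NCc1ccc(OC(F)(F)F)c(Cl)c1)C2`, gives 0.223 h. Compound 2, `CCCN(Cc1ccc(OC(F)(F)F)cc1)[C@@H]1COc2nc([N+](=O)[O-])cn2C1`, gives 0.0567 h. Compound 3, `O=[N+]([O-])c1cn2c(n1)OC[C@@H](NCc1ccc(OC(F)(F)F)cc1Cl)C2`, gives 0.332 h, the highest of the three numbers; its gap to compound 1 lies within the scatter, while its gap to compound 2 lies beyond it, so compound 2 disappears faster than compound 3.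

Compound 4, `O=[N+]([O-])c1cn2c(n1)OC[C@@H](NCc1ccc(OC(F)(F)F)cc1OCC1CC1)C2`, has not yet been measured in this assay. It differs from compound 3 in one place: cyclopropylmethoxy in place of chloro on an aromatic carbon.

Among the measured compounds shown here, no measured pair shows this kind of exchange, so the data give no direct guide to its size. The step from compound 1 to compound 3, a change of substituent pattern on the same ring, stayed within the scatter. The expected step of a 1.3-fold lower number from compound 3 to compound 4 (0.12 log units; within the scatter) is therefore small, with a slight lean toward a lower number, and may well fall within the scatter. Compound 4 is estimated at 0.25 h, with a range from 0.1 h to 0.6 h.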

Compound 4, half-life: 0.0267 h
Beside the measured number, compound 4's estimate is 9.4-fold (0.97 log units) above it; the measured number lies below the stated range.
By their numbers in this assay, from the lowest: compound 4; then compound 2; then compounds 1 and 3 (each within the scatter of the next).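

Among the compounds shown here, the step of a 12-fold lower number from compound 3 to compound 4 (1.09 log units; beyond the scatter) in this assay is the first reading of any exchange at this position, ortho to a large group and meta to a trifluoromethoxy group. It lies well beyond the scatter, so what stands on this aromatic carbon matters greatly for the half-life of this series, and cyclopropylmethoxy goes with far faster disappearance than chloro. Nothing measured here accounts for the size of this step.

The compounds shown leave open which part of the entering group goes with the loss, whether its ether oxygen, its three-membered ring or simply its five heavy atoms. From the compounds shown here alone, a methoxy group or a plain alkyl chain at this position could separate these, and it remains open whether a fluoro would behave like chloro.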